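Replacing an Amide by a Methoxyethyl Chain

The source may report more compounds than this note shows. Statements on the series, on what has been measured and on what is new or still open speak of the compounds shown alone.

Of the compounds shown here, three built on one shared core have been measured in an assay on isolated protein for displacement of a labelled ligand from 5-hydroxytryptamine receptor 6 (Homo sapiens); on this read-out higher numbers stand for weaker inhibition and lower numbers for stronger inhibition. Compound 1 `CN(C)CC1CCCc2cc(S(=O)(=O)c3ccccc3)ccc21` gives 0.0631 nM in this assay. Compound 2 `COc1cccc(S(=O)(=O)c2ccc3c(c2)CCC[C@H]3CN)c1` gives 0.398 nM. Compound 3 `O=C(NC[C@@H]1CCCc2cc(S(=O)(=O)c3cccc(F)c3)ccc21)c1ccc[nH]1` gives 5.01 nM, the highest of the three numbers and so the weakest inhibition seen here; its gap to compound 2, the nearest, and to compound 1, the furthest, both lie beyond the usual scatter.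

Compound 4 `COCCNC[C@@H]1CCCc2cc(S(=O)(=O)c3cccc(F)c3)ccc21` has not yet been measured. It differs from compound 3 in one place: 2-methoxyethyl in place of (1H-pyrrol-2-yl)carbonyl on an amine nitrogen. In compound 3 the amine nitrogen carries a carbonyl, while in compounds 1 and 2 the corresponding nitrogen carries only hydrogen or methyl groups, and in compound 4 it carries the 2-methoxyethyl chain.

Among the compounds with values here, no measured pair shows this exact change, so the expectation rests on compound 1 at 0.0631 nM and compound 2 at 0.398 nM, both with an amine free of a carbonyl and both well below compound 3. The step from compound 3 to compound 4 is expected to be a 10-fold lower number from compound 3 to compound 4 (1.00 log units; beyond the scatter), a drop in the number clearly beyond the scatter. Compound 4 is estimated to give 0.5 nM, with a range from 0.1 nM to 2.5 nM.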

Compound 4, inhibition constant: 0.251 nM
The estimate for compound 4 lay 2.0-fold (0.30 log units) above the measured number; the measured number falls inside the stated range.
By their numbers in this assay, from the lowest: compound 1; then compounds 4 and 2 (each within the scatter of the next); then compound 3.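

In this assay, within the data shown here, putting 2-methoxyethyl in place of (1H-pyrrol-2-yl)carbonyl on the amine nitrogen gives a 20-fold lower number from compound 3 to compound 4 (1.30 log units; beyond the scatter), the first step here in which only one place in the molecule changes, and it shows that the group on this nitrogen alone can shift the number by a large amount. This nitrogen can also carry a flexible chain with no ring and no carbonyl, as compound 4 gives 0.251 nM. No measurement bearing on the reason for this step is available, so the result stands as an observation only.

On these data alone, the step removes the carbonyl and the five-membered aromatic ring together, so it remains open which of them, or whether the change in group size, accounts for the lower number. An acetyl group on the same nitrogen would keep the carbonyl without the ring, a (1H-pyrrol-2-yl)methyl group would keep the ring without the carbonyl, and a plain propyl chain would test whether the oxygen of the 2-methoxyethyl chain matters.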